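The source may hold more compounds than are shown below. What is called first, only, known or untested is meant among the compounds shown, and "the series" means these compounds.

The study centres on two measured cinnamoyl-type compounds and one compound still awaiting its number. Compound 1 `CCCCS(=O)(=O)Oc1ccc(/C=C/C(=O)Nc2ccc(CC)cc2)cc1OC` was examined in a toxicity assay on L02 cells (Homo sapiens) for cytotoxicity, read by MTT assay, with a stated time of 24 h (a lower number here means that less compound is tolerated, a higher number that more compound is tolerated), and gives 89000 nM. Compound 2 `CCCOC(=O)/C=C/c1ccc(OS(=O)(=O)c2ccc(Cl)cc2)c(OC)c1` was examined in this assay and gives 150000 nM. Compound 1 holds the lower of these two numbers, but compound 2 sits close to it and the gap between the two falls within the scatter of repeated measurements, so no order between them can be claimed.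

Compound 3 `CCCCS(=O)(=O)Oc1ccc(/C=C/C(=O)Nc2ccccc2C)cc1OC` shares the core of compound 1 and differs from it in a single place: 2-methylphenyl in place of 4-ethylphenyl on an amide-type nitrogen. Because compound 1 gives 89000 nM and the change touches only the group on the amide-type nitrogen, the number for compound 3 is expected to remain close to that of compound 1. The step from compound 1 to compound 3 in this assay is therefore estimated at a 1.1-fold higher number from compound 1 to compound 3 (0.03 log units; within the scatter), which is no step beyond the scatter. Compound 3 is accordingly expected to give about 95000 nM in this assay, within a range of 40000 nM to 220000 nM.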

Compound 3, half-maximal cytotoxic concentration: 56100 nM
For compound 3 the middle estimate is 1.7-fold (0.23 log units) above the measured one; low and high end bracket the measured number.
By their numbers in this assay, from the lowest: compounds 3, 1 and 2 (each within the scatter of the next, the first and the last beyond it).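

Within the data shown here, the swap of 4-ethylphenyl for 2-methylphenyl on an amide-type nitrogen is the only change here that can be read at a single place, as compound 1 and compound 2 differ in more than one place. In this assay this swap amounts to a 1.6-fold lower number from compound 1 to compound 3 (0.20 log units; within the scatter) and therefore gives no step beyond the scatter, showing that, on the shared core, these two substituted phenyl groups cannot be told apart at this position. Nothing measured here bears on what lies behind this result.

The swap alters the alkyl group and its place on the phenyl ring together, so the compounds shown cannot separate the two, as a comparison with 2-ethylphenyl or 4-methylphenyl could. They also leave open whether a group of another kind on this nitrogen, such as a phenyl ring carrying an amine or a carboxylic acid, or a longer chain in place of the ethyl, would produce a step beyond the scatter.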